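This account rests on a few compounds, and the source may have more. Where it says the series, first, only, none or still open, it means among the compounds named here.

Measured compounds in a functional assay on CHO cells for positive allosteric modulation of metabotropic glutamate receptor 2 (Homo sapiens), read by GTPgammaS binding, with a stated time of 30 min; on this read-out lower numbers stand for an effect already at smaller amounts and higher numbers for an effect only at larger amounts of compound: compound 1 `CCc1cnc2c(C#N)c(N3CCC(c4ccccc4)CC3)ccn12` gives 501 nM; compound 2 `CCc1nnc2c(C#N)c(N3CCC(c4ccccc4)CC3)ccn12` gives 696 nM; compound 3 `CCCc1cnc2c(C#N)c(N3CCC(c4ccccc4)CC3)ccn12` gives 155 nM.

Compound 2 stands highest of the three in this assay, though compound 1 sits within the scatter of it; only compound 3 lies clearly lower. Compound 4 `N#Cc1c(N2CCC(c3ccccc3)CC2)ccn2c(CC(F)(F)F)nnc12` differs from compound 2 by trifluoromethyl in place of methyl on a saturated chain carbon bound to an aromatic carbon. Going by the values given here, the single measured step that bears on this is a 3.2-fold lower number from compound 1 to compound 3 (0.51 log units; beyond the scatter), where growing the same chain gave a modest lowering beyond the scatter. Compound 4 also enlarges that chain, with fluorines rather than a further carbon, so a lowering in this assay is expected, likely smaller than that seen for compound 3 and uncertain in size. For compound 4 the expected value is 350 nM, within 120 nM to 1000 nM. The step of a 2.0-fold lower number from compound 2 to compound 4 (0.30 log units; within the scatter) is thus the estimate.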

Compound 4, half-maximal effective concentration: 56 nM
Beside the measured number, compound 4's estimate is 6.3-fold (0.80 log units) above it; the whole stated range lies above it.
By their numbers in this assay, from the lowest: compound 4; then compound 3; then compounds 1 and 2 (each within the scatter of the next).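

In this assay, going by these compounds alone, trifluoromethyl in place of methyl on a saturated chain carbon bound to an aromatic carbon gives a 12-fold lower number from compound 2 to compound 4 (1.09 log units; beyond the scatter), while the only earlier change on this chain, on the core of compound 1, gave the modest 3.2-fold lower number from compound 1 to compound 3 (0.51 log units; beyond the scatter). This place therefore accepts the larger group, and the change to the end of the chain can shift the number well beyond the scatter. Nothing available explains the size of this step.

Going by these compounds, it remains open whether trifluoromethyl gives a similar step on the core of compound 1. Also open, on these data alone, is how a longer chain, a cyclopropyl ring or a hydroxyl group would behave at this place.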